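Urea aryl variation on the shared core: Ret V804M

This account rests on a few compounds, and the source may have more. Where it says the series, first, only, none or still open, it means among the compounds named here.

Measured compounds:
compound 1 `O=C(Nc1ccc(Br)cc1)Nc1ccc(Nc2ncnc3c2OCCN3)cc1` gives 2350 nM
compound 2 `COc1cccc(NC(=O)Nc2ccc(Nc3ncnc4c3OCCN4)cc2)c1` gives 5290 nM
compound 3 `Cc1ccc(F)c(NC(=O)Nc2ccc(Nc3ncnc4c3OCCN4)cc2)c1` gives 5110 nM

All three share one core and differ only in the aryl group on the urea nitrogen. In an assay on isolated protein for inhibition of proto-oncogene tyrosine-protein kinase receptor Ret variant V804M (Homo sapiens), read by 33P incorporation, with stated times of 15 min and 40 min (a lower number here means a stronger inhibitor, a higher number a weaker inhibitor), compound 3 sits second highest of the three numbers. Its nearest neighbour is compound 2, with a 1.0-fold lower number from compound 2 to compound 3 (0.02 log units; within the scatter), so the two are not separable. Its furthest neighbour is compound 1, with a 2.2-fold higher number from compound 1 to compound 3 (0.34 log units; beyond the scatter); the parallel comparison a 2.3-fold higher number from compound 1 to compound 2 (0.35 log units; beyond the scatter) is of the same size.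

Compound 4 `O=C(Nc1ccc(Nc2ncnc3c2OCCN3)cc1)Nc1cccc2ccccc12` carries the change (naphthalen-1-yl in place of 2-fluoro-5-methylphenyl on an amide-type nitrogen). For the measured compounds named here, no measured pair contains a naphthalen-1-yl group, so the three steps bear on it only by showing how wide this position spreads: the largest step seen, between the 4-bromophenyl and either of the two substituted phenyls, is modest, and the step between the two substituted phenyls is within the scatter. Compound 4 is therefore expected to land inside the span of the set, with a 1.5-fold lower number from compound 3 to compound 4 (0.16 log units; within the scatter) estimated and no strong direction claimed. For compound 4 the estimate in this assay is 3500 nM, with a range from 1200 nM to 10000 nM.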

Compound 4, half-maximal inhibitory concentration: > 10000 nM
Compound 4: no number, only a limit; the forecaster's own chance of this, stated with the estimate: 5%; at least 2.8-fold (0.45 log units) between middle value and limit.
By their numbers in this assay, from the lowest: compound 1; then compounds 3 and 2 (each within the scatter of the next). At a limit, above all of these: compound 4.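

In this assay compound 4, with naphthalen-1-yl on the amide-type nitrogen, gives > 10000 nM, which is a limit of the assay and not a number, so the readings at this position now run up to the end of the measured range: the limit of > 10000 nM in this assay, at which 1 of the 4 values shown sits. For the compounds shown here, only one new step clears the scatter on its floor alone, an at least 4.2-fold higher number from compound 1 to compound 4 (0.62 log units; beyond the scatter), and it shows that the 4-bromophenyl of compound 1 and the naphthalen-1-yl group can be told apart, with no gain from the group of two six-membered aromatic rings. The other two, an at least 1.9-fold higher number from compound 3 to compound 4 (0.29 log units; that floor lies within the scatter) and an at least 1.8-fold higher number from compound 2 to compound 4 (0.27 log units; that floor lies within the scatter), have floors within the scatter, so compound 4 is not yet separated from the two substituted phenyls, and the flat reading seen between those two says nothing certain about this larger group.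

As far as these compounds go, how far compound 4 lies past its limit stays unknown, so its step cannot be sized against the earlier ones. From the compounds shown here alone, whether a chlorophenyl, a pyridyl or a saturated cyclohexyl on this nitrogen would read nearer compound 1 or nearer compound 4 also stays open.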